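Homologating the Sulfonamide Arm of Compound 1

The source may hold more compounds than are shown below. What is called first, only, known or untested is meant among the compounds shown, and "the series" means these compounds.

Compound 1, `Cc1cccc(C(=O)Nc2ccc3c(c2)CC(NS(C)(=O)=O)C3)c1-c1ccc(Cl)cc1`: 100 nM
Compound 2, `Cc1cccc(C(=O)Nc2ccc3c(c2)C[C@H](NCc2ccccn2)C3)c1-c1ccc(C(F)(F)F)cc1`: 410 nM

In an assay on isolated protein for inhibition of microsomal triglyceride transfer protein large subunit (Homo sapiens) (a higher number here means a weaker inhibitor, a lower number a stronger inhibitor), compound 1 gives 100 nM, the lower of the two numbers measured. Compound 2 gives 410 nM, a gap beyond the usual scatter. Compound 3, `Cc1cccc(C(=O)Nc2ccc3c(c2)CC(CNS(C)(=O)=O)C3)c1-c1ccc(Cl)cc1`, differs from compound 1 by (methanesulfonamido)methyl in place of methanesulfonamido on a saturated ring carbon. Within the data shown here, no measured pair shows this change, so the size of the step rests on judgment alone. The estimated step of a 2.0-fold higher number from compound 1 to compound 3 (0.30 log units; within the scatter) is expected to be small, at most a modest weakening, and may fall within the scatter. Compound 3 is therefore expected to give about 200 nM in this assay, with a plausible range from 60 nM to 700 nM.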

Compound 3, half-maximal inhibitory concentration: 500 nM
Estimate against measurement, compound 3: 2.5-fold (0.40 log units) below; the measured number falls inside the stated range.
By their numbers in this assay, from the lowest: compound 1; then compounds 2 and 3 (each within the scatter of the next).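

In this assay, the one added carbon of (methanesulfonamido)methyl in place of methanesulfonamido on a saturated ring carbon weakens binding (a 5.0-fold higher number from compound 1 to compound 3 (0.70 log units; beyond the scatter)). Since the counts of hydrogen-bond donors and acceptors stay the same, this position is sensitive to where the sulfonamide sits, not only to whether it is present. Nothing measured here explains the loss.

As far as these compounds go, whether a longer chain would weaken binding further remains open. So does whether an amine or a carboxylic acid on this carbon would fare better than either sulfonamide arm.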